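From compound 3 to compound 4: cyclopropyl enters

A few compounds are considered here, and "the series" means these few. Any claim that something is new, unique, unknown or untested is made for them only; others in the source may bear on it.

Compound 1 `CC#C[C@@H](Cc1nnn[nH]1)c1ccc(OCc2ccc3scc(-c4cc(OCCOC)ccc4C)c3c2)cc1`: 0.367 h
Compound 2 `CC#C[C@@H](Cc1nnn[nH]1)c1ccc(OCc2ccc3scc(C4CCCCC4)c3c2)cc1`: 0.767 h
Compound 3 `CC#C[C@@H](Cc1nnn[nH]1)c1ccc(OCc2ccc3scc(-c4ccc(OCCOC)cc4C)c3c2)cc1`: 0.217 h

In an ADME assay on microsomes from liver (Rattus norvegicus) for metabolic stability (a higher number here means that the compound lasts longer, a lower number that the compound disappears faster), compound 3 stands at 0.217 h. It cannot be told apart from compound 1, as the measured change is a 1.7-fold lower number from compound 1 to compound 3 (0.23 log units; within the scatter). Compound 2 stands above both. Compound 4 `CC#C[C@@H](Cc1nnn[nH]1)c1ccc(OCc2ccc3scc(C4CC4)c3c2)cc1` carries cyclopropyl in place of 4-(2-methoxyethoxy)-2-methylphenyl on an aromatic carbon.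

For the measured compounds named here, no measured compound carries cyclopropyl, so the nearest guide is compound 2, with its cyclohexyl at the same place. Its exchange for the same substituted phenyl gave a 3.5-fold lower number from compound 2 to compound 3 (0.55 log units; beyond the scatter). The exchange of the other substituted phenyl for cyclohexyl gave a 2.1-fold higher number from compound 1 to compound 2 (0.32 log units; beyond the scatter). Both steps are modest, and both favour the saturated ring, so a rise of similar size is expected on leaving compound 3. The expected step is a 3.7-fold higher number from compound 3 to compound 4 (0.57 log units; beyond the scatter). For compound 4 the estimated half-life in this assay is 0.8 h, with an expected range of 0.35 h to 1.8 h.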

Compound 4, half-life: 1.72 h
Estimate against measurement, compound 4: 2.2-fold (0.33 log units) below; low and high end bracket the measured number.
By their numbers in this assay, from the lowest: compounds 3 and 1 (each within the scatter of the next); then compound 2; then compound 4.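

In this assay, cyclopropyl on the aromatic carbon two ring bonds from the ring sulfur gives the longest half-life of the four compounds, well clear of both substituted phenyls (a 7.9-fold higher number from compound 3 to compound 4 (0.90 log units; beyond the scatter)) (a 4.7-fold higher number from compound 1 to compound 4 (0.67 log units; beyond the scatter)). For the compounds shown here, the earlier compounds had set only one saturated ring against the phenyls, whereas this result shows that the saturated rings also differ among themselves, with the smaller ring standing higher (a 2.2-fold higher number from compound 2 to compound 4 (0.35 log units; beyond the scatter)). Nothing shown here accounts for these differences.

The compounds shown leave open where cyclobutyl or cyclopentyl would fall between the two saturated rings, and whether an open chain such as isopropyl would match cyclopropyl. They also leave open what an amine or an ether oxygen within the saturated ring would do to the half-life.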